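Chain variation on the shared core: estimate for compound 4

This account rests on a few compounds, and the source may have more. Where it says the series, first, only, none or still open, it means among the compounds named here.

Measured compounds:
- compound 1, `CNC(=O)C[C@@H]1C[C@@H](c2ccc(Cl)c(Cl)c2)[C@H](NC(=O)c2cc(-c3c(Cl)cnn3C)c(Cl)o2)CN1`, gives 2.64 nM in an assay for inhibition of RAC-alpha serine/threonine-protein kinase (Homo sapiens), read by HTRF, with a stated time of 1 h; a higher number here means a weaker inhibitor, a lower number a stronger inhibitor
- compound 2, `C=CC[C@@H]1C[C@@H](c2ccc(Cl)c(Cl)c2)[C@H](NC(=O)c2cc(-c3c(Cl)cnn3C)c(Cl)o2)CN1`, gives 12.4 nM in this assay
- compound 3, `Cn1ncc(Cl)c1-c1cc(C(=O)N[C@@H]2CN[C@H](CCO)C[C@H]2c2ccc(Cl)c(Cl)c2)oc1Cl`, gives 2.74 nM in this assay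

Compound 3 sits with compound 1: the step of a 1.0-fold higher number from compound 1 to compound 3 (0.02 log units; within the scatter) is within the scatter, so no order between the two can be claimed. Only compound 2 stands apart, the step of a 4.5-fold lower number from compound 2 to compound 3 (0.66 log units; beyond the scatter) and the step of a 4.7-fold higher number from compound 1 to compound 2 (0.67 log units; beyond the scatter) both being beyond the scatter.

Compound 4, `Cn1ncc(Cl)c1-c1cc(C(=O)N[C@@H]2CN[C@H](CC(=O)NCCO)C[C@H]2c2ccc(Cl)c(Cl)c2)oc1Cl`, differs from compound 3 by (2-hydroxyethyl)carbamoyl in place of hydroxymethyl on a saturated chain carbon bound to a saturated ring carbon. Among the compounds with values here, two measured steps bear on this. The step from compound 1 to compound 3 shows that a methylcarbamoyl and a hydroxymethyl at this position give numbers within the scatter of each other, and the steps involving compound 2 show that only the vinyl moves the number, and only modestly. The entering group of compound 4 is again a carbamoyl, now carrying a hydroxyethyl, so the expectation in this assay is a step of a 1.1-fold higher number from compound 3 to compound 4 (0.04 log units; within the scatter), essentially none beyond the scatter, in either direction.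

Compound 4 is therefore expected to give about 3 nM in this assay, with a range from 1.2 nM to 8 nM.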

Compound 4, half-maximal inhibitory concentration: 1.41 nM
Beside the measured number, compound 4's estimate is 2.1-fold (0.33 log units) above it, within the range that was stated.
By their numbers in this assay, from the lowest: compounds 4, 1 and 3 (each within the scatter of the next); then compound 2.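

The larger (2-hydroxyethyl)carbamoyl group on the saturated chain carbon bound to a saturated ring carbon leaves the number in this assay unresolved from that of the hydroxymethyl group, with a 1.9-fold lower number from compound 3 to compound 4 (0.29 log units; within the scatter). The amide itself can also carry more than a methyl group: hydroxymethyl in place of hydrogen on a saturated chain carbon bound to an amide-type nitrogen gives a 1.9-fold lower number from compound 1 to compound 4 (0.27 log units; within the scatter), again with no order to be claimed. Against the vinyl group the new carbamoyl gives an 8.8-fold lower number from compound 2 to compound 4 (0.94 log units; beyond the scatter), so among the four compounds the vinyl-bearing compound 2 is the only one set apart, while compound 1, compound 3 and compound 4 remain one group within the scatter.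

As far as these compounds go, whether an amine, a carboxylic acid or a longer chain ending in a methoxy group at this position would stay with that group, or fall with compound 2, remains open. No supporting data are available to account for any of these steps.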